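Urea aryl variation on the shared core

The source may hold more compounds than are shown below. What is called first, only, known or untested is meant among the compounds shown, and "the series" means these compounds.

Compound 3 `O=C(Nc1ccc([N+](=O)[O-])cc1)Nc1cccc(CNc2ncnc3ccccc23)c1` in a functional assay on HepG2 cells (Homo sapiens) for antiproliferative activity, read by MTT assay (a lower number here means a stronger inhibitor, a higher number a weaker inhibitor), gives 24600 nM. Of the two numbers shown it is the lowest, with compound 2 `O=C(Nc1ccc(F)cc1)Nc1cccc(CNc2ncnc3ccccc23)c1` nearest at 41500 nM; the step of a 1.7-fold lower number from compound 2 to compound 3 (0.23 log units; within the scatter) stays within the scatter. Compound 1 `Cc1ccccc1NC(=O)Nc1cccc(CNc2ncnc3ccccc23)c1` returns only a limit, > 50000 nM (the limit of > 50000 nM in this assay, at which 1 of the 3 values shown sits). Accordingly an at least 1.2-fold lower number from compound 1 to compound 2 (0.08 log units; that floor lies within the scatter) and an at least 2.0-fold lower number from compound 1 to compound 3 (0.30 log units; that floor lies within the scatter) are floors, not measured sizes. Compound 4 `O=C(Nc1cccc(CNc2ncnc3ccccc23)c1)Nc1cccc(C(F)(F)F)c1` differs from compound 3 by 3-(trifluoromethyl)phenyl in place of 4-nitrophenyl on an amide-type nitrogen. For the measured compounds named here, the only resolved step that bears on a change of the group on the amide-type nitrogen, a 1.7-fold lower number from compound 2 to compound 3 (0.23 log units; within the scatter), lay within the scatter, so no movement beyond the scatter is expected in this assay. Compound 4 is therefore estimated at 30000 nM, range 8000 nM to 120000 nM, meaning an expected step of a 1.2-fold higher number from compound 3 to compound 4 (0.09 log units; within the scatter).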

Compound 4, half-maximal inhibitory concentration: 40000 nM
Compound 4: middle estimate off by 1.3-fold (0.12 log units), on the low side; the measured number falls inside the stated range.
By their numbers in this assay, from the lowest: compounds 3, 4 and 2 (each within the scatter of the next). At a limit, above all of these: compound 1.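

In this assay, 3-(trifluoromethyl)phenyl gives a third measured group on the amide-type nitrogen, and both a 1.6-fold higher number from compound 3 to compound 4 (0.21 log units; within the scatter) and a 1.0-fold lower number from compound 2 to compound 4 (0.02 log units; within the scatter) stay within the scatter. Compounds 2, 3 and 4 therefore remain unseparated across 4-fluorophenyl, 4-nitrophenyl and 3-(trifluoromethyl)phenyl. Compound 1 gives a limit, so an at least 1.2-fold lower number from compound 1 to compound 4 (0.09 log units; that floor lies within the scatter) is a floor and cannot be read as a measured size: the limit of > 50000 nM in this assay, at which 1 of the 4 values shown sits.

On these data alone, whether a phenyl ring carrying an amine or a carboxylic acid on this nitrogen would move the number beyond the scatter remains open. So does the effect of replacing the phenyl ring with a longer alkyl chain.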